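The compounds below may be only part of what the source reports. "The series", "measured", "known", "first", "only" and "open" are said of these compounds alone.

Compound 3 `CN1CCN(c2ccc(OCc3ccccc3)c(NCc3ccco3)c2)CC1` holds the second highest of the three numbers measured: in an assay on HEK293 cells for displacement of a labelled ligand from 5-hydroxytryptamine receptor 6 (Homo sapiens) (a higher number here means a weaker inhibitor, a lower number a stronger inhibitor), compound 3 gives 402 nM. Compound 2 `CN1CCN(c2ccc(C#N)c(NCc3ccco3)c2)CC1` gives 1370 nM, and compound 1 `CC(Nc1cc(N2CCN(C)CC2)ccc1[N+](=O)[O-])c1ccccc1` gives 12 nM. Among the compounds with values here, the one single-point step known, a 3.4-fold lower number from compound 2 to compound 3 (0.53 log units; beyond the scatter), changes another position and does not bear on the present change. Compound 4 `CN1CCN(c2ccc(OCc3ccccc3)c(NCc3ccccc3)c2)CC1` differs from compound 3 by phenyl in place of furan-2-yl on a saturated chain carbon bound to a nitrogen on an aromatic ring. Within the data shown here, compound 1 also carries a phenyl on the amine-bearing chain but differs from compound 4 in more than one place, so its value shows only that such a compound can reach a low number. Among the measured compounds shown here, with no measured step on this change, the expected step is a 2.0-fold lower number from compound 3 to compound 4 (0.30 log units; within the scatter). Compound 4 is estimated at 200 nM, between 70 nM and 600 nM.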

Compound 4, inhibition constant: 928 nM
Estimate against measurement, compound 4: 4.6-fold (0.67 log units) below, outside the stated range (above it).
By their numbers in this assay, from the lowest: compound 1; then compound 3; then compounds 4 and 2 (each within the scatter of the next).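

On a saturated chain carbon bound to a nitrogen on an aromatic ring, phenyl in place of furan-2-yl gives a 2.3-fold higher number from compound 3 to compound 4 (0.36 log units; beyond the scatter). This position therefore responds to the ring it carries, and with benzyloxy held fixed, the furan-2-yl compound has the lower number. No measurement shown accounts for this step.

Going by these compounds, whether the step holds with cyano in place of benzyloxy remains open. Also open, on these data alone, is how a thiophene ring, a pyridine ring or a longer chain would read at this place.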